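From compound 3 to compound 4: one ring swapped

This account rests on a few compounds, and the source may have more. Where it says the series, first, only, none or still open, it means among the compounds named here.

In a physicochemical assay for solubility, in phosphate buffer, at pH 6.8 (on this read-out higher numbers stand for higher solubility and lower numbers for lower solubility), compound 1 `CCC(CC)C1C(C(=O)c2ccc(OC)cc2)=C(O)C(=O)N1c1ccc(-c2ccon2)cc1` gives 2200 nM. Putting 2-(2-hydroxyethoxy)phenyl in place of pentan-3-yl on a saturated ring carbon produces an at least 22-fold higher number from compound 1 to compound 2 (1.35 log units; beyond the scatter), and this large step is the only one measured. Compound 2 `COc1ccc(C(=O)C2=C(O)C(=O)N(c3ccc(-c4ccon4)cc3)C2c2ccccc2OCCO)cc1` reads > 50000 nM, which is a limit of the assay and not a number. Compound 3 `Cc1cc(-c2ccc(N3C(=O)C(O)=C(C(=O)C(C)(C)C)C3c3ccccc3OCCO)cc2)on1` reads > 50000 nM, which is also a limit and not a number.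

Compound 4 `CC(C)(C)C(=O)C1=C(O)C(=O)N(c2ccc(-c3ccoc3)cc2)C1c1ccccc1OCCO` keeps the 2-(2-hydroxyethoxy)phenyl group of compound 3. It differs by carrying furan-3-yl in place of 3-methyl-1,2-oxazol-5-yl on an aromatic carbon. Within the data shown here, the one measured step lies at a different place, so it offers no direct guide to this swap. It does suggest that a compound retaining that group should stay high in this assay. The expected result is an at least 1.6-fold lower number from compound 3 to compound 4 (0.22 log units; that floor lies within the scatter), a modest move towards lower numbers, if any. For compound 4 the estimated value is 30000 nM, with an expected range of 10000 nM to 50000 nM.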

Compound 4, solubility: > 50000 nM
Compound 4: a limit, no number (the forecaster's own chance of this, stated with the estimate: 40%); middle value at least 1.6-fold (0.22 log units) from the limit.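

Compound 3 and compound 4 both give a limit of the measurement and not a number, so no step can be read between them: the limit of > 50000 nM in this assay, at which 3 of the 4 values shown sit.

The compounds shown leave open whether furan-3-yl in place of 3-methyl-1,2-oxazol-5-yl changes the read-out at all, and in which direction.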